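The source may hold more compounds than are shown below. What is called first, only, known or untested is meant among the compounds shown, and "the series" means these compounds.

Compound 2 `C=C1CC[C@@H]2[C@](C)(CO)[C@H](O)CC[C@@]2(C)[C@@H]1C/C=C1/C(=O)OC[C@H]1Oc1cccc2ccc(C)nc12` and compound 1 `C=C1CC[C@@H]2[C@](C)(CO)[C@H](O)CC[C@@]2(C)[C@@H]1C/C=C1/C(=O)OC[C@H]1Oc1c(Cl)cc(Cl)c2cccnc12` are built on the same core and differ only in the group carried on an oxygen on a saturated carbon. In an ADME assay on Vero cells (Chlorocebus sabaeus) for cytotoxicity, read by MTT assay, with a stated time of 48 h (on this read-out higher numbers stand for lower toxicity in this test and lower numbers for higher toxicity in this test), compound 2 gives 61400 nM, and compound 1 gives 82500 nM. The change from compound 2 to compound 1 is 5,7-dichloroquinolin-8-yl in place of 2-methylquinolin-8-yl on an oxygen on a saturated carbon, and it made a 1.3-fold higher number from compound 2 to compound 1 (0.13 log units; within the scatter).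

Compound 3 `C=C1CC[C@H]2[C@@](C)(CCC(=O)[C@@]2(C)COC(C)=O)[C@@H]1C/C=C1/C(=O)OC[C@@H]1Oc1cccc2ccc(C)nc12` rests on a different core, and the difference between its core and that of compound 2 is not broken down here. In this assay compound 3 gives 46700 nM.

Compound 4 `C=C1CC[C@H]2[C@@](C)(CCC(=O)[C@@]2(C)COC(C)=O)[C@@H]1C/C=C1/C(=O)OC[C@@H]1Oc1c(Cl)cc(Cl)c2cccnc12` has not been measured yet. Within the data shown here, it differs from compound 3 by 5,7-dichloroquinolin-8-yl in place of 2-methylquinolin-8-yl on an oxygen on a saturated carbon, which is the same change, at the same place, as the one from compound 2 to compound 1. Because that earlier change made a 1.3-fold higher number from compound 2 to compound 1 (0.13 log units; within the scatter), the step from compound 3 to compound 4 is expected to be of a similar size, a 1.3-fold higher number from compound 3 to compound 4 (0.11 log units; within the scatter). For compound 4 in this assay the estimated value is 60000 nM, expected to lie between 30000 nM and 120000 nM.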

Compound 4, half-maximal cytotoxic concentration: 57400 nM
Estimate against measurement, compound 4: 1.0-fold (0.02 log units) above; low and high end bracket the measured number.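

In this assay, putting 5,7-dichloroquinolin-8-yl in place of 2-methylquinolin-8-yl gave a 1.2-fold higher number from compound 3 to compound 4 (0.09 log units; within the scatter), and this step matches the earlier one on the other core: the same change on two cores in this assay, a 1.3-fold higher number (0.13 log units; within the scatter) from compound 2 to compound 1 and a 1.2-fold higher number (0.09 log units; within the scatter) from compound 3 to compound 4, 1.1-fold (0.04 log units) apart, within the scatter of two such steps. In these two pairs, then, the change carried from one core to the other with no visible difference in its size. It does not show that the change itself does anything in this test: each step lies within the scatter, which makes this an agreement between two steps too small to read, a weak test of how a larger effect would carry, and it says nothing about any third core.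

The compounds shown leave open whether a different group on that oxygen, such as a plain phenyl ring or a chain ending in an amine or a carboxylic acid, would give a step beyond the scatter in this assay. They also leave open whether such a step would stay the same size on both cores.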